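An Aryl Swap on a Growth Inhibitor

A few compounds are considered here, and "the series" means these few. Any claim that something is new, unique, unknown or untested is made for them only; others in the source may bear on it.

Among the compounds with values here, in a functional assay on DU-145 cells (Homo sapiens) for inhibition, read by trypan blue exclusion, with a stated time of 96 h (a higher number here means a weaker inhibitor of growth, a lower number a stronger inhibitor of growth), compound 1 `CN(C)c1ccc(/C=C(/SCc2ccc(Br)cc2)C(=O)c2ccc(C(=O)O)cc2)cc1` gives 50000 nM, the only exact number available for this small set. Compound 2 `CN(C)c1ccc(/C=C(\C(=O)c2ccc(C(=O)O)cc2)S(=O)(=O)Cc2ccc(Cl)cc2)cc1` gives only a limit, > 100000 nM. Compound 1 therefore has a single measured neighbour, and that neighbour offers no second number to rank it against.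

Compound 3 `O=C(O)c1ccc(C(=O)/C(=C\c2ccc(O)c(Br)c2)SCc2ccc(Br)cc2)cc1` keeps the core of compound 1 but changes one group: 3-bromo-4-hydroxyphenyl in place of 4-(dimethylamino)phenyl on a double-bonded chain carbon bound to a double-bonded chain carbon. In words, 3-bromo-4-hydroxyphenyl stands in place of 4-(dimethylamino)phenyl on a double-bonded chain carbon bound to a double-bonded chain carbon.

Within the data shown here, the only measured step is an at least 2.0-fold higher number from compound 1 to compound 2 (0.30 log units; that floor lies within the scatter). It concerns a different place in the structure, and its floor lies within the scatter, so it gives no size for this change. Among the measured compounds shown here, no step at the changed place has been measured, which leaves compound 1 at 50000 nM as the sole anchor for an expectation. The expected step is a 1.3-fold lower number from compound 1 to compound 3 (0.10 log units; within the scatter), which means no shift beyond the scatter and no firm direction in this assay. Compound 3 is expected at 40000 nM, with an estimated range of 10000 nM to 100000 nM.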

Compound 3, concentration for 50% growth inhibition: 25000 nM
For compound 3 the middle estimate is 1.6-fold (0.20 log units) above the measured one; the measured number falls inside the stated range.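

In this assay, the exchange of 4-(dimethylamino)phenyl for 3-bromo-4-hydroxyphenyl on a double-bonded chain carbon bound to a double-bonded chain carbon gives a 2.0-fold lower number from compound 1 to compound 3 (0.30 log units; within the scatter). Within the data shown here, this is the first step read at this place, and it shows that the place accepts a rather different aryl group, with a hydrogen-bond donor and a bromine entering and the dimethylamino nitrogen leaving, without a shift beyond the scatter. The set now also holds two exact numbers on the core of compound 1, but they lie within the scatter of each other and so give no ranking of the two aryl groups.

Compound 2 remains a limit and not a number, so the sulfur side of the molecule still has no measured size to set beside this step: the limit of > 100000 nM in this assay, at which 1 of the 3 values shown sits. The swap also brings in the hydroxyl and the bromine together, which leaves their separate contributions open, and whether a methoxy group or a nitrile on the same aryl ring would move the number beyond the scatter also remains unanswered.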